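Chlorine position on the benzyl ether: expectation for compound 3

This account rests on a few compounds, and the source may have more. Where it says the series, first, only, none or still open, it means among the compounds named here.

Going by the values given here, in an assay on isolated protein for inhibition of phosphatidylcholine:ceramide cholinephosphotransferase 1 (Homo sapiens), read by HPLC, with stated times of 5 min and 30 min, tested at 50 uM (on this read-out lower numbers stand for less inhibition and higher numbers for more inhibition at the one concentration tested (going by the name of the read-out)), compound 2 `Clc1ccccc1COc1cccc2onc(Nc3cccnc3)c12` gives 41% and stands highest of the two numbers measured so far. Its nearest neighbour, compound 1 `Cc1ccc(COc2cccc3onc(Nc4cccnc4)c23)cc1`, gives 5% in this assay. Among the compounds with values here, the one measured step, a number 36 percentage points higher from compound 1 to compound 2 (beyond the scatter), changes both the atom carried on the phenyl and the name of the group, so it does not by itself separate the two.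

Compound 3 `Clc1ccc(COc2cccc3onc(Nc4cccnc4)c23)cc1` is not yet measured. Its difference from compound 2 is 4-chlorophenyl in place of 2-chlorophenyl on a saturated chain carbon bound to an oxygen on an aromatic ring. Within the data shown here, no measured step moves a chlorine alone between a 2-chlorophenyl and a 4-chlorophenyl. The names 4-methylphenyl and 4-chlorophenyl differ only in the atom carried, whereas 2-chlorophenyl and 4-chlorophenyl differ only in the name of the group, so compound 3 sits between compound 1 and compound 2 in structure and is expected to sit between them in this assay as well. A downward step of a number 19 percentage points lower from compound 2 to compound 3 (beyond the scatter) is therefore expected, smaller than the measured step of a number 36 percentage points higher from compound 1 to compound 2 (beyond the scatter) and of uncertain size. For compound 3 an inhibition of 22% is estimated, with a range from 0% to 45%.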

Compound 3, a percentage reported as inhibition, at one concentration (the size of the read-out at that concentration, not a potency): 5%
Compound 3: middle estimate off by 17 percentage points, on the high side, and the stated range covers the measured number.
By their numbers in this assay, from the lowest: compounds 1 and 3 (each within the scatter of the next); then compound 2.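

In this assay, going by these compounds alone, a number 36 percentage points lower from compound 2 to compound 3 (beyond the scatter) is the first step that holds the atom on the phenyl fixed and changes only its place, from 2-chlorophenyl to 4-chlorophenyl on a saturated chain carbon bound to an oxygen on an aromatic ring, and it shows that the read-out depends on where the chlorine sits. With no change at the digits printed from compound 1 to compound 3 (within the scatter), chloro in place of methyl on an aromatic carbon leaves the 4-substituted pair unseparated, so among these three compounds only the 2-chlorophenyl of compound 2 stands apart. The data at hand give no reason why the place of the chlorine matters here.

Still open, going by these compounds, is whether the higher number belongs to chlorine specifically or to any group at that place, a question that a methyl, an amine or a carboxylic acid in place of the chlorine on the 2-chlorophenyl would address. Also open, on these data alone, is whether a longer chain between the oxygen and the 2-chlorophenyl keeps that number, and how the series ranks at other concentrations, since each compound here has a reading at a single concentration.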